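The source may hold more compounds than are shown below. What is called first, only, known or untested is meant among the compounds shown, and "the series" means these compounds.

In a functional assay on B16 cells (Mus musculus) for cytotoxicity (a higher number here means a weaker inhibitor, a lower number a stronger inhibitor), compound 1 `COc1ccc(/C=C\c2cc(OC)c(OC)c(OC)c2)cc1B(O)O` gives 6.3 nM and compound 2 `COc1cc(/C=C\c2cccc(B(O)O)c2)cc(OC)c1OC` gives 490 nM, so compound 2 holds the higher of the two numbers. Compound 3 `COc1cc(/C=C\c2cccc(B(O)O)c2)cc(OC)c1` differs from compound 2 by hydrogen in place of methoxy on an aromatic carbon, ortho to two methoxy groups and para to a large group. For the measured compounds named here, one measured step bears on this, the same kind of replacement at a different place, which gave a 78-fold higher number from compound 1 to compound 2 (1.89 log units; beyond the scatter), a large step. No measurement exists yet for the replacement at this place, so that step guides the direction more than the size. A higher number in this assay is expected, by a moderate to large step. The expected change is a 4.1-fold higher number from compound 2 to compound 3 (0.61 log units; beyond the scatter). For compound 3 the estimated value is 2000 nM, with a range of 600 nM to 8000 nM.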

Compound 3, half-maximal inhibitory concentration: 1800 nM
Compound 3: middle estimate off by 1.1-fold (0.05 log units), on the high side; low and high end bracket the measured number.
By their numbers in this assay, from the lowest: compound 1; then compound 2; then compound 3.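

Removing the methoxy that sits ortho to two methoxy groups and para to a large group still matters in this assay, with a 3.7-fold higher number from compound 2 to compound 3 (0.57 log units; beyond the scatter) at this place, so this methoxy contributes to the potency of compound 2. The same replacement at the other place gave a 78-fold higher number from compound 1 to compound 2 (1.89 log units; beyond the scatter) in the same assay, so the direction repeats across the two places while the size is modest here and large there, and the two methoxy positions do not count equally in this pair of steps. Nothing available explains the difference between the two places.

Open, on these data alone, is whether a hydroxyl, an ethoxy or a fluorine at this place would keep the number of compound 2 or fall nearer that of compound 3. Also open, as far as these compounds go, is whether the same two steps would keep their sizes on a core carrying a carboxylic acid instead of the boronic acid.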